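Side-chain change on the shared core: cytotoxicity notes

The compounds below may be only part of what the source reports. "The series", "measured", "known", "first", "only" and "open" are said of these compounds alone.

Measured in an ADME assay on A549 cells (Homo sapiens) for cytotoxicity, read by resazurin assay, with a stated time of 48 h; a lower number here means that less compound is tolerated, a higher number that more compound is tolerated:
- compound 1 `CC(C)CNc1ccc(NC(=O)c2cc(Cl)ccc2O)c(Cl)c1` gives 60000 nM
- compound 2 `O=C(Nc1ccc(NCc2ccc3cn[nH]c3c2)cc1Cl)c1cc(Cl)ccc1O` gives 45300 nM

The two measured compounds cannot be told apart, so compound 2 stands level with compound 1 on these numbers. Compound 3 `CC(C)(C)OC(=O)NCCNc1ccc(NC(=O)c2cc(Cl)ccc2O)c(Cl)c1` changes the same place again: ((tert-butoxycarbonyl)amino)methyl in place of 1H-indazol-6-yl on a saturated chain carbon bound to a nitrogen on an aromatic ring. Within the data shown here, only one measured step bears on this change, a 1.3-fold lower number from compound 1 to compound 2 (0.12 log units; within the scatter), where isopropyl gave way to 1H-indazol-6-yl. With so little evidence, no step beyond the scatter is expected in this assay, in either direction. The estimated move is a 1.1-fold higher number from compound 2 to compound 3 (0.04 log units; within the scatter). For compound 3 the expected value is 50000 nM, with an estimated range from 25000 nM to 95000 nM.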

Compound 3, half-maximal cytotoxic concentration: 25000 nM
The estimate for compound 3 lay 2.0-fold (0.30 log units) above the measured number; low and high end bracket the measured number.
By their numbers in this assay, from the lowest: compounds 3, 2 and 1 (each within the scatter of the next, the first and the last beyond it).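

In this assay, the ringless ((tert-butoxycarbonyl)amino)methyl in place of 1H-indazol-6-yl gives a 1.8-fold lower number from compound 2 to compound 3 (0.26 log units; within the scatter) with no separation at this position, so the two aromatic rings are not needed to hold the number in this range. Against isopropyl, the same group gives a 2.4-fold lower number from compound 1 to compound 3 (0.38 log units; beyond the scatter) as the first step here to clear the scatter, though only modestly. No available evidence accounts for this step. Still open, on these data alone, is whether a free primary amine or a carboxylic acid at this position would move the number further, and whether a longer chain would do the same.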